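The source may report more compounds than this note shows. Statements on the series, on what has been measured and on what is new or still open speak of the compounds shown alone.

Measured in a functional assay on RKO cells (Homo sapiens) for cytotoxicity, read by resazurin assay, with a stated time of 72 h; on this read-out higher numbers stand for weaker inhibition and lower numbers for stronger inhibition:
- Compound 1 `COc1cccc(Nc2nc(-n3cc(C)nc3C)cs2)c1`: 60000 nM
- Compound 2 `c1ccc(Nc2nc(-n3cnc4ccccc43)cs2)cc1`: > 100000 nM (a limit)
- Compound 3 `COc1ccc(Nc2nc(-n3cnc4ccccc43)cs2)cc1`: > 100000 nM (a limit)

Compound 2 stands at the limit of > 100000 nM in this assay, at which 2 of the 3 values shown sit, so it has no exact number. Compound 4 `Cc1nc2ccccc2n1-c1csc(Nc2ccccc2)n1` has methyl in place of hydrogen on an aromatic carbon. Among the compounds with values here, the one measured step, a step that the two limits leave unreadable from compound 2 to compound 3, places methoxy in place of hydrogen on an aromatic carbon, and it offers no size to carry over. Compound 1 alone gives a number, 60000 nM. Only a small step towards stronger inhibition, or none, is therefore expected in this assay, and a further limit is quite possible. The expected step is an at least 1.1-fold lower number from compound 2 to compound 4 (0.04 log units; that floor lies within the scatter). For compound 4 the estimated value is 90000 nM, with an expected range of 40000 nM to 180000 nM.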

Compound 4, half-maximal inhibitory concentration: 50000 nM
For compound 4 the middle estimate is 1.8-fold (0.26 log units) above the measured one; the range from low to high includes it.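

In this assay, within the data shown here, methyl in place of hydrogen on the aromatic carbon between two ring nitrogen atoms gives the first step on this core with a readable size: an at least 2.0-fold lower number from compound 2 to compound 4 (0.30 log units; that floor lies within the scatter). From the compounds shown here alone, compound 2 still has only a limit, > 100000 nM, so compound 4 supplies the exact number and the true size of the step stays unknown. The step from compound 2 to compound 3 cannot be read.

Going by these compounds, whether an amine or a longer chain at this carbon would give a lower number remains open. So does whether methyl would act the same way alongside the methoxy of compound 3.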